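The source may report more compounds than this note shows. Statements on the series, on what has been measured and on what is new or still open speak of the compounds shown alone.

Compound 1 `CCCc1ccc(-c2cc(Cl)cc(C(=O)Nc3nn[nH]n3)n2)cc1` gives 78% in a functional assay on the whole organism with Rattus norvegicus as the target, at a dose of 1 mg/kg by the oral route; a higher number here means a stronger effect of the compound at the dose given, a lower number a weaker effect. Compound 2 `CCCCc1ccc(-c2cc(Cl)cc(C(=O)Nc3nn[nH]n3)n2)cc1` carries methyl in place of hydrogen on a saturated chain carbon, three bonds along the chain from an aromatic carbon and gives 0% in this assay, so that a number 78 percentage points lower from compound 1 to compound 2 (beyond the scatter). Compound 3 `CCc1ccc(-c2cc(OC)cc(C(=O)Nc3nn[nH]n3)n2)cc1` stands on another core; the difference between the two cores is not broken down here. In this assay compound 3 gives 43%. Compound 4 `CCCc1ccc(-c2cc(OC)cc(C(=O)Nc3nn[nH]n3)n2)cc1` has not been measured; it carries methyl in place of hydrogen on a saturated chain carbon, two bonds along the chain from an aromatic carbon. Going by the values given here, this is the same kind of change as the one between compound 1 and compound 2, yet not the same: there the methyl enters three bonds along the chain from an aromatic carbon, here two bonds along the chain from an aromatic carbon, and on a different core. Among the compounds with values here, only one measured step of this kind exists, and it sits at another place, so the expectation is uncertain; a smaller step is expected, namely a number 7 percentage points higher from compound 3 to compound 4 (within the scatter). Compound 4 is thus estimated at 50%, somewhere between 10% and 85%.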

Compound 4, a percentage reported as inhibition, in the whole organism at one dose (the size of the read-out at that dose, not a potency): 73%
For compound 4 the middle estimate is 23 percentage points below the measured one; low and high end bracket the measured number.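

Methyl in place of hydrogen on the chain gives a number 30 percentage points higher from compound 3 to compound 4 (beyond the scatter) in this assay, and the effect of this change does not carry over unchanged from the core of compound 1: the same change on two cores in this assay, a number 78 percentage points lower (beyond the scatter) from compound 1 to compound 2 and a number 30 percentage points higher (beyond the scatter) from compound 3 to compound 4, 108 percentage points apart, beyond the scatter of two such steps

This does not show that the core alone sets the outcome, as the two steps also differ in place, with the methyl entering two bonds along the chain from an aromatic carbon in one and three bonds along in the other. With the propyl chain held, methoxy in place of chloro on an aromatic carbon leaves a number 5 percentage points lower from compound 1 to compound 4 (within the scatter).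

As far as these compounds go, it remains open whether a butyl chain on the core of compound 3 would match compound 2. The response to a pentyl chain, or to an amine on the aromatic carbon bearing chloro or methoxy, is also unknown.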